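The compounds below may be only part of what the source reports. "The series", "measured", "known", "first", "only" and "open" are said of these compounds alone.

Measured so far:
- compound 1, `COc1ccc2ccc(=O)oc2c1C(/C=C/c1ccc(SC)cc1)=N/NC(N)=O`: 99 nM
- compound 2, `COc1ccc2ccc(=O)oc2c1C1=NN(C(C)=O)C(c2ccccc2)C1`: 52 nM

In a functional assay on HepG2 cells (Homo sapiens) for cytotoxicity, read by MTT assay, with a stated time of 72 h (a lower number here means a stronger inhibitor, a higher number a weaker inhibitor), compound 1 gives 99 nM and compound 2 gives 52 nM; the two numbers sit within the usual scatter of each other, so neither compound can be called the stronger. Compound 3, `COc1ccc2ccc(=O)oc2c1C(/C=C/c1cccs1)=N/NC(N)=O`, has not yet been measured in this assay. It differs from compound 1 by thiophen-2-yl in place of 4-(methylsulfanyl)phenyl on a double-bonded chain carbon bound to a double-bonded chain carbon. Within the data shown here, no measured pair shows a step of this kind, so the step of a 1.4-fold higher number from compound 1 to compound 3 (0.15 log units; within the scatter) is only an expectation, and a small one, not clearly beyond the scatter. For compound 3 the expected value is 140 nM, within a range from 45 nM to 450 nM.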

Compound 3, half-maximal inhibitory concentration: 75 nM
For compound 3 the middle estimate is 1.9-fold (0.27 log units) above the measured one; measured number inside the range.
By their numbers in this assay, from the lowest: compounds 2, 3 and 1 (each within the scatter of the next).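

In this assay, among these compounds, thiophen-2-yl in place of 4-(methylsulfanyl)phenyl gives the first readable step at this position (a 1.3-fold lower number from compound 1 to compound 3 (0.12 log units; within the scatter)), and it lies within the scatter. A five-membered aromatic ring with fewer heavy atoms can therefore replace the six-membered one here without a clear change in the number. Nothing available gives a reason for this result.

The compounds shown leave open whether this position needs an aromatic ring at all. An amine or a carboxylic acid in its place could show how much change it tolerates.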